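The source may hold more compounds than are shown below. What is called first, only, known or untested is meant among the compounds shown, and "the series" means these compounds.

Compound 1, whose structure is `COc1cc(-c2cc(/C=C/C(=O)c3ccc(N)cc3)[nH]n2)cc(OC)c1OC`, is one of three compounds with a shared core that differ in the groups attached to it. In a functional assay on OVCAR-5 cells (Homo sapiens) for inhibition, read by sulforhodamine B assay, with a stated time of 48 h (a lower number here means a stronger inhibitor of growth, a higher number a weaker inhibitor of growth), compound 1 gives 3750 nM, the second highest of the three numbers. Compound 3, with the structure `COc1cc(C(=O)/C=C/c2cc(-c3cc(OC)c(OC)c(OC)c3)n[nH]2)cc(OC)c1OC`, gives 3120 nM in this assay, within the scatter of compound 1. Among the compounds with values here, compound 2, the structure `COc1ccc(-c2cc(/C=C/C(=O)c3ccc(N)cc3)[nH]n2)cc1OC`, gives 7940 nM, and the step of a 2.1-fold higher number from compound 1 to compound 2 (0.33 log units; beyond the scatter) is the only change measured in one place: hydrogen in place of methoxy on an aromatic carbon.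

Compound 4 has the structure `COc1cc(-c2cc(/C=C/C(=O)c3ccc(F)c(F)c3)[nH]n2)cc(OC)c1OC`. It differs from compound 1 by 3,4-difluorophenyl in place of 4-aminophenyl on a carbonyl carbon. Within the data shown here, no measured step touches the group on the carbonyl carbon, so the measured step from compound 1 to compound 2 gives no direct guide; it shows only that a single change elsewhere on the shared core moved this assay modestly. On that basis the change to compound 4 is expected to be at most modest in this assay, in either direction. Compound 4 is therefore estimated at 5000 nM, in the range 1500 nM to 16000 nM, which means an expected step of a 1.3-fold higher number from compound 1 to compound 4 (0.12 log units; within the scatter).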

Compound 4, concentration for total growth inhibition: 33800 nM
Compound 4: middle estimate off by 6.8-fold (0.83 log units), on the low side; the whole stated range lies below it.
By their numbers in this assay, from the lowest: compounds 3 and 1 (each within the scatter of the next); then compound 2; then compound 4.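

On the carbonyl carbon, the swap to 3,4-difluorophenyl gives a 9.0-fold higher number from compound 1 to compound 4 (0.95 log units; beyond the scatter) in this assay, which is larger than the step for hydrogen in place of methoxy, a 2.1-fold higher number from compound 1 to compound 2 (0.33 log units; beyond the scatter), so this position clearly affects growth inhibition. The group that leaves carries a hydrogen-bond donor and acceptor, whereas the group that enters has neither and brings fluorine instead, so several features change together and this single step cannot separate them. Nothing measured here accounts for the weaker growth inhibition.

On these data alone, it remains open whether the amine itself matters, which an unsubstituted phenyl or a phenyl bearing a hydroxyl or a single fluorine on the carbonyl carbon could help test. As far as these compounds go, it is also open whether 3,4-difluorophenyl would have a similar effect on the core of compound 2.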